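Conjugate series: ring fluorination step and expected potency

The source may report more compounds than this note shows. Statements on the series, on what has been measured and on what is new or still open speak of the compounds shown alone.

Three conjugates on one shared core have been measured in a functional assay on Bel-7402 cells (Homo sapiens) for antiproliferative activity, read by MTT assay, with a stated time of 72 h; a lower number here means a stronger inhibitor, a higher number a weaker inhibitor. Compound 1 `C=C1C(=O)O[C@H]2[C@H]1CC/C(COC(=O)Cn1cc(F)c(=O)n(Cc3ccccc3)c1=O)=C\CC[C@@]1(C)O[C@@H]21` gives 3980 nM and stands at the lowest of the two numbers in hand. Compound 2 `C=C1C(=O)O[C@H]2[C@H]1CC/C(Cn1cc(Cn3cc(F)c(=O)n(Cc4ccccc4)c3=O)nn1)=C\CC[C@@]1(C)O[C@@H]21` gives 9160 nM, a higher number than compound 1 by a step beyond the scatter. For compound 3 `C=C1C(=O)O[C@H]2[C@H]1CC/C(COC(=O)CCC(=O)N1CCN(C(=O)Cn3cc(F)c(=O)n(Cc4ccccc4)c3=O)CC1)=C\CC[C@@]1(C)O[C@@H]21` only a limit of the assay is recorded, > 20000 nM; the relevant note is the limit of > 20000 nM in this assay, at which 1 of the 3 values shown sits. Compound 4 `C=C1C(=O)O[C@H]2[C@H]1CC/C(COC(=O)Cn1cc(F)c(=O)n(Cc3ccc(F)c(F)c3)c1=O)=C\CC[C@@]1(C)O[C@@H]21` is not yet measured in this assay . It differs from compound 1 in one place: 3,4-difluorophenyl in place of phenyl on a saturated chain carbon bound to an aromatic nitrogen. Within the data shown here, no measured pair shows this change, so its size is open; a step within the scatter, in either direction, is expected. Compound 4 is expected to give 3500 nM, between 1500 nM and 8000 nM, and the expected step is a 1.1-fold lower number from compound 1 to compound 4 (0.06 log units; within the scatter).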

Compound 4, half-maximal inhibitory concentration: 2700 nM
Compound 4: the middle estimate sits 1.3-fold (0.11 log units) above what was measured; measured number inside the range.
By their numbers in this assay, from the lowest: compounds 4 and 1 (each within the scatter of the next); then compound 2. At a limit, above all of these: compound 3.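

Replacing phenyl with 3,4-difluorophenyl gives a 1.5-fold lower number from compound 1 to compound 4 (0.17 log units; within the scatter) in this assay, the first step read at this place, on a saturated chain carbon bound to an aromatic nitrogen. At this position, then, the change does not move the number beyond the scatter. Nothing in hand bears on a cause for this step. Open, from the compounds shown here alone, is whether an amine or a carboxylic acid on this aromatic ring, or a longer chain in place of the benzyl carbon, would give a step beyond the scatter.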